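Two Limits in One Series and a Dichlorophenyl Variant

This account rests on a few compounds, and the source may have more. Where it says the series, first, only, none or still open, it means among the compounds named here.

Measured compounds:
compound 1 `N#CC1=C(N)Oc2c(c3nc4ccccc4nc3c3ccccc23)C12C(=O)N(Cc1cnnn1-c1ccccc1Br)c1ccccc12`: > 50000 nM
compound 2 `Cc1ccccc1-n1nncc1CN1C(=O)C2(C(C#N)=C(N)Oc3c(N)cc4nc5ccccc5nc4c32)c2ccccc21`: > 50000 nM

Compound 1 `N#CC1=C(N)Oc2c(c3nc4ccccc4nc3c3ccccc23)C12C(=O)N(Cc1cnnn1-c1ccccc1Br)c1ccccc12` was tested in a functional assay on MCF7 cells (Homo sapiens) for antiproliferative activity, read by MTT assay, with a stated time of 48 h (a lower number here means a stronger inhibitor, a higher number a weaker inhibitor), and gives > 50000 nM, which is a limit of the assay and not a number. Compound 2 `Cc1ccccc1-n1nncc1CN1C(=O)C2(C(C#N)=C(N)Oc3c(N)cc4nc5ccccc5nc4c32)c2ccccc21` gives > 50000 nM in this assay, again a limit rather than a number. Compound 2 therefore stands at the ceiling of what is shown: the limit of > 50000 nM in this assay, at which 2 of the 2 values shown sit. For the measured compounds named here, no step between two measured numbers exists here, so nothing indicates how far a change at the aromatic nitrogen moves activity in this assay.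

Compound 3 `N#CC1=C(N)Oc2c(N)cc3nc4ccccc4nc3c2C12C(=O)N(Cc1cnnn1-c1cc(Cl)ccc1Cl)c1ccccc12` differs from compound 2 in one place: 2,5-dichlorophenyl in place of 2-methylphenyl on an aromatic nitrogen. With both known values at the limit, the expected step that the limit leaves unreadable from compound 2 to compound 3 is estimated as none beyond the scatter, in no particular direction. Compound 3 is estimated at 60000 nM, within 20000 nM to 200000 nM.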

Compound 3, half-maximal inhibitory concentration: 33200 nM
Compound 3: middle estimate off by 1.8-fold (0.26 log units), on the high side; the measured number falls inside the stated range.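

In this assay, for the compounds shown here, compound 3 gives 33200 nM, the first actual number, so the aryl group on the aromatic nitrogen can be changed to give a reading rather than a limit. Replacing 2-methylphenyl with 2,5-dichlorophenyl at this position gives an at least 1.5-fold lower number from compound 2 to compound 3 (0.17 log units; that floor lies within the scatter), a floor on the step and not its full size. The other values shown remain at the limit of the assay: the limit of > 50000 nM in this assay, at which 2 of the 3 values shown sit.

The true size of this step remains unknown, and the compounds shown do not separate the contribution of either chlorine. Also open, going by these compounds, is how an unsubstituted phenyl, a 2-chlorophenyl, a 3-chlorophenyl or a 2-methoxyphenyl group at the same position would read in this assay.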